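Methyl on the chloromethyl carbon: compound 3 to compound 4

The source may hold more compounds than are shown below. What is called first, only, known or untested is meant among the compounds shown, and "the series" means these compounds.

Measured so far:
compound 1 `O=C(O)/C=C/C(=O)Nc1cccc(-c2nc3ccccc3s2)c1` gives > 25000 nM in an ADME assay on Raji cells (Homo sapiens) for inhibition, with a stated time of 72 h (on this read-out higher numbers stand for an effect only at larger amounts of compound and lower numbers for an effect already at smaller amounts), which is a limit of the assay.
compound 2 `CN(C)CCC(=O)Nc1cccc(-c2nc3ccccc3s2)c1` gives > 25000 nM in this assay, again a limit.
compound 3 `O=C(CCl)Nc1cccc(-c2nc3ccccc3s2)c1` gives 1700 nM in this assay.

Among the measured compounds shown here, compound 3 holds the only real number in the set; the other two entries sit at the limit (the limit of > 25000 nM in this assay, at which 2 of the 3 values shown sit). The steps of an at least 14-fold lower number from compound 1 to compound 3 (1.16 log units; beyond the scatter) and an at least 14-fold lower number from compound 2 to compound 3 (1.16 log units; beyond the scatter) are large, both reaching the chloromethyl carbonyl from a different group, while a step that the two limits leave unreadable from compound 1 to compound 2 cannot be read because the limit of > 25000 nM in this assay, at which 2 of the 3 values shown sit, covers both ends.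

Compound 4 `CC(Cl)C(=O)Nc1cccc(-c2nc3ccccc3s2)c1` differs from compound 3 by methyl in place of hydrogen on a saturated chain carbon bound to a carbonyl carbon and a chlorine atom. For the measured compounds named here, no measured step touches the chain carbon while keeping its chlorine: the two readable steps swap the whole group on the carbonyl carbon or exchange a (dimethylamino)methyl for chloro, so the chlorine that distinguishes compound 3 is retained in compound 4. The expected step in this assay is therefore modest, a 2.1-fold higher number from compound 3 to compound 4 (0.31 log units; beyond the scatter), toward a somewhat higher number. Compound 4 is estimated at 3500 nM, within 1200 nM to 12000 nM.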

Compound 4, half-maximal effective concentration: > 25000 nM
Compound 4: a limit, no number (the forecaster's own chance of this, stated with the estimate: 15%); middle value at least 7.1-fold (0.85 log units) from the limit.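

On the saturated chain carbon bound to a carbonyl carbon and a chlorine atom, methyl in place of hydrogen is no small change in this assay: the step is an at least 14-fold higher number from compound 3 to compound 4 (1.16 log units; beyond the scatter). Among the compounds shown here, compound 4 keeps the chlorine, so chlorine on this carbon does not on its own secure a readable value, and compound 3 remains the only compound with one. The steps from compound 1 and from compound 2 to compound 4 cannot be read, and compound 4 is a third entry at the limit: the limit of > 25000 nM in this assay, at which 3 of the 4 values shown sit.

From the compounds shown here alone, how far compound 4 lies past its limit remains open. So does the response of this carbon to other changes, such as a bromomethyl group in place of chloromethyl or an ethyl group in place of the added methyl.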